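Dropping One Hydroxy from Compound 1: Expected Cytotoxicity

The source may report more compounds than this note shows. Statements on the series, on what has been measured and on what is new or still open speak of the compounds shown alone.

Measured compounds:
compound 1 `COc1ccc(Cc2coc3cc(O)cc(O)c3c2=O)cc1` — in a functional assay on H9c2 cells (Mus musculus) for cytotoxicity against H9c2 (Rattus norvegicus), read by MTT assay, with a stated time of 24 h (a higher number here means that more compound is needed for the effect, a lower number that less compound is needed), compound 1 gives > 100000 nM, a limit of the assay
compound 2 `COc1ccc(Cc2coc3cc(O)cc(O)c3c2=O)cc1OC` — in this assay compound 2 gives 12100 nM

Compound 1 stands only at a limit in this assay: the limit of > 100000 nM in this assay, at which 1 of the 2 values shown sits. Among the measured compounds shown here, the one measured step, an at least 8.2-fold lower number from compound 1 to compound 2 (0.91 log units; beyond the scatter), describes a methoxy added on the pendant ring, far from the change considered here.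

Compound 3 `COc1ccc(Cc2coc3cccc(O)c3c2=O)cc1` differs from compound 1 by hydrogen in place of hydroxy on an aromatic carbon. For the measured compounds named here, no measured step touches this hydroxy, so the only guide is that compound 1 sits at a limit and that the single known change, an at least 8.2-fold lower number from compound 1 to compound 2 (0.91 log units; beyond the scatter), concerns another place altogether. For compound 3 the expectation is therefore a number close to where compound 1 stands, with no step beyond the scatter foreseen and a fair chance that the assay again reports only a limit.

Compound 3 is thus estimated at 100000 nM in this assay, in a range from 30000 nM to 300000 nM.

This estimate corresponds to the step of a number no higher from compound 1 to compound 3 (the limit leaves the size open), which is expected to be small.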

Compound 3, half-maximal effective concentration: > 100000 nM
Compound 3: a limit, no number; the forecaster's own chance of this, stated with the estimate: 60%; the middle value sits exactly at the limit.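

In this assay compound 3 gives > 100000 nM, a limit of the assay and not a number. Among the compounds shown here, compound 1 and compound 3 both stand at a limit, so no step between them can be read: the limit of > 100000 nM in this assay, at which 2 of the 3 values shown sit. The compounds shown leave open whether hydrogen in place of this hydroxy changes the number in this assay at all.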